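The source may report more compounds than this note shows. Statements on the series, on what has been measured and on what is new or still open speak of the compounds shown alone.

Measured so far:
compound 1 `S=C(N/N=C/c1ccc(Oc2ccc3ccccc3c2)cc1)Nc1ccc(Cl)cc1` — 6.96
compound 2 `S=C(N/N=C/c1ccc(Oc2ccc3ccccc3c2)cc1)Nc1ccc(Br)cc1` — 6.93

In a physicochemical assay for lipophilicity, in phosphate buffer, measured as octanol-water partition, with a stated time of 24 h (a lower number here means a more polar compound, a higher number a more lipophilic compound), compound 1 gives 6.96, the higher of the two numbers, though its nearest neighbour compound 2, with 6.93, lies within the scatter of it. For the measured compounds named here, the one measured step, a number 0.03 log units lower from compound 1 to compound 2 (within the scatter), changes nothing beyond the scatter.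

Compound 3 `S=C(N/N=C/c1ccc(Oc2ccc(Cl)cc2)cc1)Nc1ccc(Cl)cc1` differs from compound 1 in another place: 4-chlorophenyl in place of naphthalen-2-yl on an oxygen on an aromatic ring. Going by the values given here, no measured step concerns this part of the core of compound 1; the step from compound 1 to compound 2 sits on the other aromatic ring and so does not bear on it. The expectation for compound 3 therefore rests only on the change itself, with a naphthalen-2-yl group leaving and a 4-chlorophenyl group entering. Compound 3 is expected to come out somewhat lower, a step of a number 0.46 log units lower from compound 1 to compound 3 (beyond the scatter). The estimate for compound 3 in this assay is 6.5, with a range from 6 to 6.9.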

Compound 3, partition coefficient: 6.2
For compound 3 the middle estimate is 0.30 log units above the measured one, within the range that was stated.
By their numbers in this assay, from the lowest: compound 3; then compounds 2 and 1 (each within the scatter of the next).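

In this assay, for the compounds shown here, the group on an oxygen on an aromatic ring proves to be a place where the number moves, with a number 0.76 log units lower from compound 1 to compound 3 (beyond the scatter), while the only earlier step, a number 0.03 log units lower from compound 1 to compound 2 (within the scatter), lay on the other aromatic ring and stayed inside the scatter. The change replaces naphthalen-2-yl, with 2 six-membered aromatic rings of carbon only, by 4-chlorophenyl, with one such ring, and neither group carries a hydrogen-bond donor, a hydrogen-bond acceptor or a net charge. Nothing measured here accounts for the size of this step.

From the compounds shown here alone, whether the same step would appear with the bromo group of compound 2 in place of the chloro group remains open. Also open, going by these compounds, is how the number would respond on this oxygen to a group of another kind, such as a short alkyl chain bearing an amine or a carboxylic acid.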